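Swapping the Aryl Amide for a Pyridinyl Amide

A few compounds are considered here, and "the series" means these few. Any claim that something is new, unique, unknown or untested is made for them only; others in the source may bear on it.

Measured so far:
compound 1 `Cc1cc(C)cc(NC(=O)COc2cc(C)nc3ccc(C(F)(F)F)cc23)c1` – 10000 nM
compound 2 `COc1ccc2nc(C)cc(OCC(=O)Nc3ccc(Br)c(C)c3)c2c1` – < 1000 nM

Compound 1 `Cc1cc(C)cc(NC(=O)COc2cc(C)nc3ccc(C(F)(F)F)cc23)c1` gives 10000 nM in a physicochemical assay for solubility, in phosphate buffer, measured as kinetic solubility, with a stated time of 1 h, at pH 7.4; on this read-out lower numbers stand for lower solubility and higher numbers for higher solubility. Compound 2 `COc1ccc2nc(C)cc(OCC(=O)Nc3ccc(Br)c(C)c3)c2c1` stands differently: in this assay compound 2 gives < 1000 nM, which is a limit of the assay rather than a number. That reading sits at the limit of < 1000 nM in this assay, at which 1 of the 2 values shown sits, so for compound 2 only a boundary is known and no exact value.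

Compound 3 `COc1ccc2nc(C)cc(OCC(=O)Nc3c(C)cncc3C)c2c1` is the untested compound. It keeps the whole of compound 2 except for one exchange on the amide-type nitrogen whose other neighbour is the carbonyl carbon: 3,5-dimethylpyridin-4-yl in place of 4-bromo-3-methylphenyl on an amide-type nitrogen

Going by the values given here, no two measured compounds here differ in a single place, so no measured step can guide this change. My expectation for the move from compound 2 to compound 3 is nonetheless a rise in this assay that is larger than the scatter, and the estimated step is an at least 10-fold higher number from compound 2 to compound 3 (1.00 log units; beyond the scatter). On that basis compound 3 is expected to reach about 10000 nM, with a likely range from 1500 nM to 80000 nM.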

Compound 3, solubility: 12000 nM
Estimate against measurement, compound 3: 1.2-fold (0.08 log units) below; measured number inside the range.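

In this assay, going by these compounds alone, putting 3,5-dimethylpyridin-4-yl in place of 4-bromo-3-methylphenyl on the amide-type nitrogen gives an at least 12-fold higher number from compound 2 to compound 3 (1.07 log units; beyond the scatter), so this position can carry a large change in the read-out, and this is the first comparison here between compounds that differ in a single place. The value of compound 2 is a limit of the assay and not a number, so the step is known only as a minimum: the limit of < 1000 nM in this assay, at which 1 of the 3 values shown sits. The two groups have the same count of heavy atoms, and the exchange replaces a bromine and a ring carbon with a ring nitrogen, which counts as a hydrogen-bond acceptor.

The compounds shown do not separate the arrival of the ring nitrogen from the departure of the bromine, and they do not tell whether the same exchange would give a similar step on the core of compound 1. Also open, as far as these compounds go, is what an aminoethyl chain or a carboxylic acid on the amide-type nitrogen would do in this assay.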